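Dropping the tolylsulfonyl amino group from compound 3

A few compounds are considered here, and "the series" means these few. Any claim that something is new, unique, unknown or untested is made for them only; others in the source may bear on it.

Within the data shown here, in a functional assay on HCT-116 cells (Homo sapiens) for antiproliferative activity, read by MTT assay, with a stated time of 72 h (on this read-out lower numbers stand for stronger inhibition and higher numbers for weaker inhibition), compound 3 `Cc1ccc(S(=O)(=O)NCc2cn(C[C@H](O)[C@H]3OC(=O)C(OCc4ccccc4)=C3OCc3ccccc3)nn2)cc1` gives 13100 nM, the lowest of the three numbers so far. Compound 1 `O=C1O[C@H]([C@@H](O)Cn2cc(CCCCl)nn2)C(OCc2ccccc2)=C1OCc1ccccc1` gives 36100 nM and compound 2 `C[Si](C)(C)c1cn(C[C@H](O)[C@H]2OC(=O)C(OCc3ccccc3)=C2OCc2ccccc2)nn1` gives 31800 nM; a 1.1-fold lower number from compound 1 to compound 2 (0.06 log units; within the scatter) stays within the scatter. Unmeasured compound 4 `O=C1O[C@H]([C@@H](O)Cn2cc(CCO)nn2)C(OCc2ccccc2)=C1OCc1ccccc1` differs from compound 3 by hydroxymethyl in place of ((4-methylphenyl)sulfonyl)amino on a saturated chain carbon bound to an aromatic carbon, which puts hydroxymethyl in place of ((4-methylphenyl)sulfonyl)amino on a saturated chain carbon bound to an aromatic carbon. Among the measured compounds shown here, two measured steps bear on this, a 2.8-fold lower number from compound 1 to compound 3 (0.44 log units; beyond the scatter) and a 2.4-fold lower number from compound 2 to compound 3 (0.39 log units; beyond the scatter), both modest and beyond the scatter. Neither compound 1 nor compound 2 carries that group, so a modest rise in this assay is expected, of the size a 2.3-fold higher number from compound 3 to compound 4 (0.36 log units; beyond the scatter). The estimate for compound 4 is 30000 nM, within an expected range of 14000 nM to 65000 nM.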

Compound 4, half-maximal inhibitory concentration: 72700 nM
Beside the measured number, compound 4's estimate is 2.4-fold (0.38 log units) below it; measured number above the stated range.
By their numbers in this assay, from the lowest: compound 3; then compounds 2, 1 and 4 (each within the scatter of the next, the first and the last beyond it).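

In this assay, hydroxymethyl in place of ((4-methylphenyl)sulfonyl)amino gives a 5.5-fold higher number from compound 3 to compound 4 (0.74 log units; beyond the scatter), so compound 3 now stands apart from a third compound without that group. The other steps differ: a 2.3-fold higher number from compound 2 to compound 4 (0.36 log units; beyond the scatter) lies beyond the scatter, while a 2.0-fold higher number from compound 1 to compound 4 (0.30 log units; within the scatter) stays within it, so this assay does not separate the chlorine-ended and hydroxy-ended chains. Nothing available explains these steps. Which part of the ((4-methylphenyl)sulfonyl)amino group carries the difference stays open. So does whether an amine or a carboxylic acid here would read like compound 3 or compound 4.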